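A few compounds are considered here, and "the series" means these few. Any claim that something is new, unique, unknown or untested is made for them only; others in the source may bear on it.

The measured compounds and their values in a functional assay on PC-12 cells (Rattus norvegicus) for cytotoxicity, read by MTT assay, with stated times of 2 h and 24 h, tested at 10 uM; on this read-out higher numbers stand for a stronger effect at the one concentration tested and lower numbers for a weaker effect:

compound 1 `CCc1ccc(-n2nc(-c3ccc(C(F)(F)F)cc3O)nc2-c2ccccc2O)cc1`: 107%
compound 2 `Oc1cc(C(F)(F)F)ccc1-c1nc(-c2ccccc2O)n(-c2ccc(Br)cc2)n1`: 100%
compound 3 `Oc1cc(C(F)(F)F)ccc1-c1nc(-c2ccccc2O)n(-c2ccc(I)cc2)n1`: 105%

Compound 1 gives the highest of the three numbers in this assay, but its steps to the other two are small: a number 7 percentage points lower from compound 1 to compound 2 (within the scatter) and a number 2 percentage points lower from compound 1 to compound 3 (within the scatter), both within the scatter, so the three compounds cannot be ranked on these data. The step between the two halogen analogues, a number 5 percentage points higher from compound 2 to compound 3 (within the scatter), is likewise within the scatter.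

Compound 4 `Oc1cc(C(F)(F)F)ccc1-c1nc(-c2ccccc2O)n(-c2ccc(C(F)(F)F)cc2)n1` differs from compound 1 in one place: trifluoromethyl in place of ethyl on an aromatic carbon. Among the measured compounds shown here, the steps that bear on this change are the two that also replace the ethyl on the same aromatic carbon, from compound 1 to compound 2 and from compound 1 to compound 3; neither moved the read-out beyond the scatter. For the measured compounds named here, no measured step involves a trifluoromethyl at this position, so the only guidance is that two different replacements of the ethyl here left the number essentially unchanged. A step of no more than the usual scatter is therefore expected in this assay, in no particular direction.

Compound 4 is expected to give 103% in this assay, with a range from 90% to 115%. The expected step is a number 4 percentage points lower from compound 1 to compound 4 (within the scatter).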

Compound 4, a percentage reported as activity, at one concentration (the size of the read-out at that concentration, not a potency): 102%
Beside the measured number, compound 4's estimate is 1 percentage points above it; the range from low to high includes it.
By their numbers in this assay, from the lowest: compounds 2, 4, 3 and 1 (each within the scatter of the next).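

In this assay, trifluoromethyl on this aromatic carbon, para to a large group, gives a number that cannot be told apart from those of the ethyl, bromo and iodo compounds, with steps reading a number 5 percentage points lower from compound 1 to compound 4 (within the scatter) and a number 3 percentage points lower from compound 3 to compound 4 (within the scatter) and a number 2 percentage points higher from compound 2 to compound 4 (within the scatter). The earlier steps had tested only the exchange of ethyl for a single halogen atom, whereas this one brings in a group of four heavy atoms, and the read-out still does not move beyond the scatter, so all four compounds shown form one group with no ranking among them. Nothing available explains why this position tolerates these four groups alike in this read-out.

The compounds shown leave open whether an amine, a carboxylic acid or a longer chain such as butyl at this position would give a number beyond the scatter, since every group seen so far leaves the read-out in the same narrow band. They also leave open what happens when the core changes, for example when either hydroxyl group of the shared core is replaced by methoxy, and how these compounds behave at any other concentration.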